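From hydroxymethyl to ethyl: compound 3 to compound 4

The source may hold more compounds than are shown below. What is called first, only, known or untested is meant among the compounds shown, and "the series" means these compounds.

Values in a physicochemical assay for solubility (on this read-out higher numbers stand for higher solubility and lower numbers for lower solubility), so far:
Compound 1 `CNC(=O)c1cc(C(=O)NC2CC2)cc2c1OC[C@H]2c1cccc2[nH]ccc12` gives >= 142 ug/mL (a limit)
Compound 2 `CNC(=O)c1cc(C(=O)N[C@H]2[C@@H]3COC[C@@H]32)cc2c1OC[C@H]2c1cccc(OC)c1` gives >= 186 ug/mL (a limit)
Compound 3 `CNC(=O)c1cc(C(=O)N[C@H]2[C@@H]3COC[C@@H]32)cc2c1OC[C@@]2(CO)c1ccccc1` gives >= 202 ug/mL (a limit)

Compound 3 stands at >= 202 ug/mL (a limit and not a number). Compounds 1 and 2 also stand at limits, so no order among the three can be read. Compound 4 `CC[C@@]1(c2ccccc2)COc2c(C(=O)NC)cc(C(=O)N[C@H]3[C@@H]4COC[C@@H]43)cc21` has not yet been measured and differs from compound 3 thus: methyl in place of hydroxy on a saturated chain carbon bound to a saturated ring carbon (methyl in place of hydroxy on a saturated chain carbon bound to a saturated ring carbon, or hydroxymethyl to ethyl). Among the compounds with values here, no measured pair shows this change. The expectation leans on compound 2, which lacks the hydroxymethyl and gives >= 186 ug/mL (again a limit). In this assay a small downward move or none beyond the scatter is expected, an estimated at least 1.1-fold lower number from compound 3 to compound 4 (0.07 log units; that floor lies within the scatter) (expected, not measured). The estimate for compound 4 is 170 ug/mL (expected range 60 ug/mL to 205 ug/mL).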

Compound 4, solubility: >= 152 ug/mL
Compound 4 was reported as a limit; the forecaster's own chance of this, stated with the estimate: 50%; the middle value is on the limit's open side.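

In this assay compound 3 gives the limit >= 202 ug/mL. Compound 4 gives the limit >= 152 ug/mL. Within the data shown here, no step from compound 3 to compound 4 can be read from these two limits. The compounds shown leave open whether hydroxymethyl to ethyl moves the read-out in this assay at all.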